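Sugar-like Ring Replacing a Dihydroxypropyl Chain on the Triazole

The compounds below may be only part of what the source reports. "The series", "measured", "known", "first", "only" and "open" are said of these compounds alone.

Compound 1 `O=C1c2c[n+]([O-])c3ccccc3c2C(=O)c2c1c1ccccc1n2Cc1cn(C[C@H](O)CO)nn1` is the starting point. In a toxicity assay on L02 cells (Homo sapiens) for cytotoxicity, read by MTT assay, with a stated time of 72 h (on this read-out lower numbers stand for stronger inhibition and higher numbers for weaker inhibition), compound 1 gives 1130 nM, the highest of the two numbers measured. Within the data shown here, its nearest neighbour is compound 2 `O=C1c2c[n+]([O-])c3ccccc3c2C(=O)c2c1c1ccccc1n2CCN1CCCC1`, which in this assay gives 930 nM; the only measured step, a 1.2-fold lower number from compound 1 to compound 2 (0.08 log units; within the scatter), lies within the scatter. Compound 3 `O=C1c2c[n+]([O-])c3ccccc3c2C(=O)c2c1c1ccccc1n2Cc1cn([C@H]2C[C@H](O)[C@@H](CO)O2)nn1` has not yet been measured. Relative to compound 1, the change is 4-hydroxy-5-(hydroxymethyl)oxolan-2-yl in place of 2,3-dihydroxypropyl on an aromatic nitrogen. Among the measured compounds shown here, the one measured step swaps out the whole triazole-bearing arm and so does not touch the part changed here; it also left the number essentially unchanged. There is therefore nothing to point toward a move beyond the scatter, and the expected step is no change at the digits printed from compound 1 to compound 3 (within the scatter), that is, none of note. Compound 3 is thus expected to give about 1130 nM, with a likely range from 500 nM to 2600 nM.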

Compound 3, half-maximal inhibitory concentration: 280 nM
Estimate against measurement, compound 3: 4.0-fold (0.61 log units) above; measured number below the stated range.
By their numbers in this assay, from the lowest: compound 3; then compounds 2 and 1 (each within the scatter of the next).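

In this assay there is a 4.0-fold lower number from compound 1 to compound 3 (0.61 log units; beyond the scatter) when 4-hydroxy-5-(hydroxymethyl)oxolan-2-yl replaces 2,3-dihydroxypropyl on an aromatic nitrogen. This is the first step among these compounds to lie beyond the scatter, and it shows that the group at this position can shift the number, even though the donor count stays the same and the change remains far from the shared core. The earlier step to compound 2 could not show this, as it replaced the whole triazole-bearing arm and stayed within the scatter; nothing measured here explains the shift.

The compounds shown leave open whether the ring itself, its hydroxymethyl arm, its ring hydroxyl or its defined stereocentres account for the lower number. A plain oxolan-2-yl group, or a ring carrying an amine in place of a hydroxyl, at this position would help to separate these parts.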